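The compounds below may be only part of what the source reports. "The series", "measured", "known", "first", "only" and "open" are said of these compounds alone.

This study measures how strongly a small set of compounds holds back the growth of a human cancer cell line, in an ADME assay on PA-1 cells (Homo sapiens) for cytotoxicity, read by MTT assay, with a stated time of 72 h; a higher number here means a weaker inhibitor, a lower number a stronger inhibitor. Of the compounds shown here, three have values so far. Compound 1 `COCOc1cc(C2=C(c3cc(OC)c(OC)c(OC)c3)C(=O)CC2O[SiH2]C(C)(C)C)ccc1OC` gives 13.5 ug/mL. Compound 3 `CCOC(=O)COc1ccc(C2=C(c3cc(OC)c(OC)c(OC)c3)C(=O)CC2O)cc1` reaches only the limit of the test, > 100 ug/mL, so no number is known for it. Compound 2 `C=CCOc1cc(C2=C(c3cc(OC)c(OC)c(OC)c3)C(=O)C(O)C2)ccc1OC` likewise reaches only the limit, > 100 ug/mL, and this is where it stands among the values shown: at the limit of > 100 ug/mL in this assay, at which 2 of the 3 values shown sit, not at a measured number.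

The next compound, compound 4 `COc1ccc(C2=C(c3cc(OC)c(OC)c(OC)c3)C(=O)C(O)C2)cc1OC(C)C`, differs from compound 2 in a single place (isopropyl in place of allyl on an oxygen on an aromatic ring). Among the compounds with values here, no measured pair in this set differs in just one place, so there is no measured step to lean on. Because compound 2 sits at the limit of > 100 ug/mL in this assay, at which 2 of the 3 values shown sit, the step of a number no higher from compound 2 to compound 4 (the limit leaves the size open) is expected to be none beyond the scatter, most likely ending again at the limit. Compound 4 is therefore estimated at 100 ug/mL, with a range from 40 ug/mL to 200 ug/mL.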

Compound 4, half-maximal inhibitory concentration: > 100 ug/mL
Compound 4: a limit, no number (the forecaster's own chance of this, stated with the estimate: 70%); the middle value lies on the limit itself.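

Compound 2 and compound 4 both end at a limit rather than a number in this assay, so no step can be read between them: the limit of > 100 ug/mL in this assay, at which 3 of the 4 values shown sit.

The compounds shown leave open how allyl and isopropyl on an oxygen on an aromatic ring truly compare.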